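From Methylsulfanyl to Methoxycarbonyl on a Shared Core

The source may report more compounds than this note shows. Statements on the series, on what has been measured and on what is new or still open speak of the compounds shown alone.

Of the compounds shown here, three sharing one core have been measured so far in an ADME assay on HEK293 cells (Homo sapiens) for cytotoxicity, with a stated time of 72 h; on this read-out lower numbers stand for an effect already at smaller amounts and higher numbers for an effect only at larger amounts of compound. Compound 1 `Cc1cc(NC(=O)Nc2ccc(C)c(Cl)c2)c2ccccc2n1` gives > 25000 nM, which is a limit of this assay and not a true number. Compound 3 `Cc1cc(NC(=O)Nc2cccc([N+](=O)[O-])c2)c2ccccc2n1` gives > 25000 nM, and this too is only a limit. Within the data shown here, compound 2 `CSc1ccc(NC(=O)Nc2cc(C)nc3ccccc23)cc1` gives 24000 nM, the only actual number among the three.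

Compound 4 `COC(=O)c1ccc(NC(=O)Nc2cc(C)nc3ccccc23)cc1` is the next to be measured, and it differs from compound 2 in one place: methoxycarbonyl in place of methylsulfanyl on an aromatic carbon. Methoxycarbonyl takes the place of methylsulfanyl on an aromatic carbon, para to a large group.

Among the measured compounds shown here, no measured pair differs in just one place, so no earlier step shows how large such a change might be. For the measured compounds named here, the only guide is compound 2, at 24000 nM. Compound 1 and compound 3 both reach a limit of this assay, even though their groups differ. The expected change is a 1.0-fold higher number from compound 2 to compound 4 (0.02 log units; within the scatter), which means no step beyond the usual scatter and no favoured direction. Compound 4 is estimated at 25000 nM, with an expected range from 12000 nM to 50000 nM.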

Compound 4, half-maximal effective concentration: 15000 nM
Compound 4: the middle estimate sits 1.7-fold (0.22 log units) above what was measured; low and high end bracket the measured number.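

Among these compounds, this is the first pair in this assay that differs in one place, so it gives the first direct look at a change at this position on the ring. Replacing methylsulfanyl with methoxycarbonyl, para to a large group, gives a 1.6-fold lower number from compound 2 to compound 4 (0.20 log units; within the scatter), so these two groups cannot be told apart here, even though they differ in their atoms and methoxycarbonyl brings a double bond outside the aromatic rings. Compound 2 and compound 4 both give actual numbers rather than a limit, which is what allows this step to be read at all, and the assay's ceiling lies close to both of them: the limit of > 25000 nM in this assay, at which 2 of the 4 values shown sit.

On these data alone, whether a group of a different kind at this position, such as an amine, a carboxylic acid or a longer chain, would shift the number beyond the usual scatter stays open. Steps to compound 1 and compound 3 cannot be read, so the shared core offers no comparison yet of what changes elsewhere on this ring would do.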